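The source may report more compounds than this note shows. Statements on the series, on what has been measured and on what is new or still open speak of the compounds shown alone.

Compound 3 `COc1cc(Cl)cc(-c2nn(-c3cccc(NC(=O)c4cc(C(F)(F)F)cc(C(F)(F)F)c4)c3)cc2-c2ccncc2)c1` stands highest of the three measured compounds in a functional assay on U-251 cells (Homo sapiens) for inhibition, read by sulforhodamine B assay, with a stated time of 48 h, tested at 10 uM (a higher number here means a weaker effect of the compound at the concentration tested, a lower number a stronger effect), where compound 3 gives 60.7%. Its nearest neighbour on the numbers is compound 1 `COc1cc(Cl)cc(-c2nn(-c3cccc(NC(=O)Nc4cccc(C(F)(F)F)c4)c3)cc2-c2ccncc2)c1`, which in this assay gives 4.59%, and furthest from it lies compound 2 `COc1cc(Cl)cc(-c2nn(-c3cccc(NC(=O)Nc4ccc(Cl)c(C(F)(F)F)c4)c3)cc2-c2ccncc2)c1`, which in this assay gives -48.3%; both of those gaps are beyond the scatter.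

Compound 4 `COc1cc(Cl)cc(-c2nn(-c3cccc(NC(=O)c4cccc(C(F)(F)F)c4)c3)cc2-c2ccncc2)c1` differs from compound 3 in one place: hydrogen in place of trifluoromethyl on an aromatic carbon.

Among the compounds with values here, only one measured step bears on this at all, and only loosely: going from the urea of compound 1 to that of compound 2, chloro in place of hydrogen on an aromatic carbon, gave a number 52.9 percentage points lower from compound 1 to compound 2 (beyond the scatter), a strengthening of effect on gaining a halogen-bearing group. Within the data shown here, the step from compound 3 to compound 4 runs the other way, losing a trifluoromethyl, so a weakening, that is a higher number, is expected for compound 4 in this assay, of a size around a number 11.3 percentage points higher from compound 3 to compound 4 (beyond the scatter), though with wide uncertainty since no direct counterpart exists. Compound 4 is therefore estimated at 72%, within a range of 45% to 100%.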

Compound 4, a percentage reported as activity, at one concentration (the size of the read-out at that concentration, not a potency): 49.2%
Compound 4: the middle estimate sits 22.8 percentage points above what was measured; the measured number falls inside the stated range.
By their numbers in this assay, from the lowest: compound 2; then compound 1; then compound 4; then compound 3.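

In this assay hydrogen in place of trifluoromethyl on an aromatic carbon gives a number 11.5 percentage points lower from compound 3 to compound 4 (beyond the scatter) and so a modestly stronger effect, which shows that a trifluoromethyl group at this place on the aromatic ring is not needed for the effect seen with compound 3. Within the data shown here, compound 4 also isolates the link for the first time: with the 3-(trifluoromethyl)phenyl group kept, replacing the urea with the amide gives a number 44.6 percentage points higher from compound 1 to compound 4 (beyond the scatter) and so a much weaker effect. The remaining step gives a number 97.5 percentage points higher from compound 2 to compound 4 (beyond the scatter) and changes the chloro and the link together, so it cannot be read as a single change.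

From the compounds shown here alone, whether a nitrile or a methyl group at this place would keep, strengthen or weaken the effect remains open. No measurement given here explains why either step goes the way it does.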